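A few compounds are considered here, and "the series" means these few. Any claim that something is new, unique, unknown or untested is made for them only; others in the source may bear on it.

Compound 1 `COc1cccc(-c2nn(-c3ccccc3)cc2-c2ccnc(NCCCNC(=O)c3cccc(C(F)(F)F)c3)c2)c1` and compound 2 `COc1cccc(-c2nn(-c3ccccc3)cc2-c2ccnc(NCCNC(=O)Nc3cccc(C(F)(F)F)c3)c2)c1` share one core. In a functional assay on NCI/ADR-RES cells (Homo sapiens) for antiproliferative activity (a higher number here means a weaker inhibitor of growth, a lower number a stronger inhibitor of growth), compound 1 gives 3540 nM, the highest of the two numbers; compound 2 gives 2220 nM, which lies within the scatter of the result for compound 1. Compound 3 `COc1cccc(-c2nn(-c3ccccc3)cc2-c2ccnc(NCCCNC(=O)Nc3ccc(Cl)c(Cl)c3)c2)c1` arises from compound 1 by (3,4-dichlorophenyl)amino in place of 3-(trifluoromethyl)phenyl on a carbonyl carbon, cut one bond further out a change from (3-(trifluoromethyl)phenyl)carbonyl to (3,4-dichlorophenyl)carbamoyl. Among the measured compounds shown here, no measured pair isolates this change. The expected step in this assay is a 1.3-fold lower number from compound 1 to compound 3 (0.10 log units; within the scatter), nothing beyond the scatter. Compound 3 is estimated at 2800 nM, with a range from 1200 nM to 6500 nM.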

Compound 3, concentration for 50% growth inhibition: 2190 nM
Beside the measured number, compound 3's estimate is 1.3-fold (0.11 log units) above it, and the stated range covers the measured number.
By their numbers in this assay, from the lowest: compounds 3, 2 and 1 (each within the scatter of the next).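

Placing (3,4-dichlorophenyl)amino in place of 3-(trifluoromethyl)phenyl on a carbonyl carbon gives, in this assay, a 1.6-fold lower number from compound 1 to compound 3 (0.21 log units; within the scatter). This position therefore carries either group, including one with an added nitrogen and hydrogen-bond donor, without a step beyond the scatter, although the nitrogen and the ring substituents change together. Nothing available explains this result. The compounds shown leave open what the nitrogen and the two chlorines each contribute alone. They also leave open how an unsubstituted phenyl, an aliphatic amine or a carboxylic acid would read at this position.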